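This account rests on a few compounds, and the source may have more. Where it says the series, first, only, none or still open, it means among the compounds named here.

Measured so far:
- compound 1 `COc1cc(Oc2cccc(Nc3ccccc3)c2)cc(OC)c1CNCc1ccc(Br)cc1`: in a functional assay on HCT-116 cells (Homo sapiens) for inhibition, read by MTT assay, with a stated time of 72 h (a higher number here means a weaker inhibitor, a lower number a stronger inhibitor), compound 1 gives 6230 nM
- compound 2 `COc1cc(Oc2cccc(Nc3ccccc3)c2)cc(OC)c1CNCc1ccc(Cl)cc1`: in this assay compound 2 gives 3310 nM
- compound 3 `COc1cc(Oc2cccc(Nc3ccccc3)c2)cc(OC)c1CNC1CC1`: in this assay compound 3 gives > 20000 nM, which is a limit of the assay and not a measured number

Compound 3 therefore stands at the weak end of what has been seen: its value is only a limit, set at the limit of > 20000 nM in this assay, at which 1 of the 3 values shown sits. Compounds 1 and 2 share its core and differ only in the group on the amine nitrogen; the step of a 1.9-fold lower number from compound 1 to compound 2 (0.27 log units; within the scatter) lies within the scatter, so these two are not ordered against each other.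

Compound 4 `COc1ccc(CNCc2c(OC)cc(Oc3cccc(Nc4ccccc4)c3)cc2OC)cc1` has not yet been measured. It differs from compound 3 by 4-methoxybenzyl in place of cyclopropyl on an amine nitrogen.

For the measured compounds named here, two measured steps bear on this change. Going the other way, from a benzyl group to cyclopropyl, gave an at least 3.2-fold higher number from compound 1 to compound 3 (0.50 log units; beyond the scatter) and an at least 6.0-fold higher number from compound 2 to compound 3 (0.78 log units; beyond the scatter). Restoring a benzyl group is thus expected to bring the number back down, roughly into the range of compounds 1 and 2, though a methoxy group in place of a halogen is untested here. The expected step is an at least 3.3-fold lower number from compound 3 to compound 4 (0.52 log units; beyond the scatter). Compound 4 is estimated at 6000 nM, with a likely range from 2500 nM to 20000 nM.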

Compound 4, half-maximal inhibitory concentration: 2620 nM
Compound 4: the middle estimate sits 2.3-fold (0.36 log units) above what was measured, and the stated range covers the measured number.
By their numbers in this assay, from the lowest: compounds 4, 2 and 1 (each within the scatter of the next, the first and the last beyond it). At a limit, above all of these: compound 3.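

In this assay, putting 4-methoxybenzyl in place of cyclopropyl on the amine nitrogen gives an at least 7.6-fold lower number from compound 3 to compound 4 (0.88 log units; beyond the scatter). A benzyl group at this position thus need not carry a halogen to keep the number in the range of compounds 1 and 2. Methoxy in place of chloro gives a 1.3-fold lower number from compound 2 to compound 4 (0.10 log units; within the scatter) and leaves those two compounds not ordered against each other, whereas methoxy in place of bromo gives a 2.4-fold lower number from compound 1 to compound 4 (0.38 log units; beyond the scatter) as a modest gain. The step from cyclopropyl can be read only as a minimum, since compound 3 stands at a limit of the assay: the limit of > 20000 nM in this assay, at which 1 of the 4 values shown sits.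

On these data alone, what a plain benzyl group with nothing on its ring would give remains open, as does the effect of a hydroxy group or an amine in place of methoxy. As far as these compounds go, it is also open whether a straight alkyl chain on the amine nitrogen would behave like cyclopropyl or like the benzyl groups.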